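The compounds below may be only part of what the source reports. "The series", "measured", "known", "first", "only" and "open" are said of these compounds alone.

Two compounds with a shared core have been examined, and a third awaits testing. For compound 1 `O=C(NCc1ccccc1)c1nccnc1Cl` no result is reported in an ADME assay on HeLa cells (Homo sapiens) for cytotoxicity, read by microscopy, with a stated time of 6 days; a higher number here means that more compound is tolerated, a lower number that less compound is tolerated; its entry reads "not determined" (no result reported). Compound 2 `CCCCCCNc1nccnc1C(=O)NCc1ccccc1` has the only entry, and that entry is a limit of the assay rather than a number: in this assay compound 2 gives > 100000 nM. This stands at the limit of > 100000 nM in this assay, at which 1 of the 2 values shown sits. Compound 3 `CCCCCCCNc1nccnc1C(=O)NCc1ccccc1` differs from compound 2 by methyl in place of hydrogen on a saturated chain carbon, six bonds along the chain from a nitrogen on an aromatic ring. For the measured compounds named here, with no measured step available, the step of a number no higher from compound 2 to compound 3 (the limit leaves the size open) is expected to stay within the usual scatter. Compound 3 is therefore estimated at 100000 nM, between 50000 nM and 200000 nM, most likely again reported only as a limit.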

Compound 3, minimum cytotoxic concentration: > 100000 nM
Compound 3: no number, only a limit; the forecaster's own chance of this, stated with the estimate: 80%; the middle value lies on the limit itself.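

In this assay, for the compounds shown here, compound 2 and compound 3 both give only a limit, not a number, so no step between them can be read. Open remains the concentration at which either compound would harm the cells, and whether the added methyl changes it.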